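Cytotoxicity notes: aryl and heteroaryl variants on the pyridine core

The compounds below may be only part of what the source reports. "The series", "measured", "known", "first", "only" and "open" are said of these compounds alone.

Measured so far:
- compound 1 `COc1nc(C(C)(C)C)ccc1[C@@H](c1ccccc1)[C@@](O)(CCN(C)C)c1cccc2ccccc12`: 27.6 ug/mL
- compound 2 `COc1nc(-c2cccc(F)c2)ccc1[C@@H](c1ccccc1)[C@@](O)(CCN(C)C)c1cccc2ccccc12`: > 50 ug/mL

In a toxicity assay on Vero cells (Chlorocebus sabaeus) for cytotoxicity (a higher number here means that more compound is tolerated, a lower number that less compound is tolerated), compound 1 gives 27.6 ug/mL. For compound 2 this assay reports only a limit, > 50 ug/mL; that is where compound 2 stands, at the limit of > 50 ug/mL in this assay, at which 1 of the 2 values shown sits. Within the data shown here, the one measured step, an at least 1.8-fold higher number from compound 1 to compound 2 (0.25 log units; that floor lies within the scatter), is itself no more than a floor.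

Compound 3 `COc1nc(-c2cnsc2)ccc1[C@@H](c1ccccc1)[C@@](O)(CCN(C)C)c1cccc2ccccc12` differs from compound 2 by 1,2-thiazol-4-yl in place of 3-fluorophenyl on an aromatic carbon. Among the measured compounds shown here, no measured step covers this exchange of one aromatic ring for another, so no step beyond the scatter is expected in this assay, an at least 1.1-fold lower number from compound 2 to compound 3 (0.04 log units; that floor lies within the scatter). Compound 3 is therefore estimated at 45 ug/mL, between 22 ug/mL and 90 ug/mL.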

Compound 3, half-maximal cytotoxic concentration: 26.3 ug/mL
The estimate for compound 3 lay 1.7-fold (0.23 log units) above the measured number, and the stated range covers the measured number.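

Compound 3 puts a five-membered aromatic ring with 2 hetero atoms at this position, and the exchange for tert-butyl does not separate the two compounds in this assay: a 1.0-fold lower number from compound 1 to compound 3 (0.02 log units; within the scatter). Against the 3-fluorophenyl ring the result is an at least 1.9-fold lower number from compound 2 to compound 3 (0.27 log units; that floor lies within the scatter), so this exchange of aromatic rings is not shown to move the number beyond the scatter. Compound 2 remains a limit, which leaves that step only a floor: the limit of > 50 ug/mL in this assay, at which 1 of the 3 values shown sits.

Going by these compounds, how a primary amine, a carboxylic acid or a longer alkyl chain would read at this position stays open. So does the true number for compound 2.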